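Amine substituent variation: compound 3 to compound 4

The source may hold more compounds than are shown below. What is called first, only, known or untested is meant among the compounds shown, and "the series" means these compounds.

Measured so far in an assay on CHO cells for agonist activity at 5-hydroxytryptamine receptor 1D (Homo sapiens), read by GTPgammaS binding; a lower number here means that less compound is needed, a higher number that more compound is needed for the effect:
- compound 1 `c1ccc(C2CCCCN2C2CCN(CCCc3c[nH]c4ccc(-n5cnnc5)cc34)CC2)cc1`: 4.7 nM
- compound 2 `CC(=O)Nc1ccc(CNC2CCN(CCCc3c[nH]c4ccc(-n5cnnc5)cc34)CC2)cc1`: 5 nM
- compound 3 `CC(C)=CCN(C)C1CCN(CCCc2c[nH]c3ccc(-n4cnnc4)cc23)CC1`: 1.8 nM

Compound 3 carries the lowest number of the three. Its nearest neighbour is compound 1, whose number is higher by a margin beyond the scatter, and the gap to compound 2 is of similar size, also beyond the scatter. Compounds 1 and 2 themselves sit within the scatter of each other, so no order between them is claimed.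

Compound 4 `CN(Cc1cccs1)C1CCN(CCCc2c[nH]c3ccc(-n4cnnc4)cc23)CC1` is the next compound to be measured. It differs from compound 3 in one place: thiophen-2-yl in place of 2-methylprop-1-en-1-yl on a saturated chain carbon bound to an amine nitrogen. The rest of the structure, including the shared core and the chain linking it to the piperidine nitrogen, is unchanged.

Among the compounds with values here, no step between measured compounds isolates this kind of change, so the expectation rests on the three values alone. All three numbers lie in a narrow band despite quite different amine substituents, which suggests the amine position tolerates variation. The step of a 1.8-fold higher number from compound 3 to compound 4 (0.25 log units; within the scatter) is expected to be a small rise, within or only just beyond the scatter. Compound 4 is therefore estimated at 3.2 nM, with a range from 1.2 nM to 9 nM.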

Compound 4, half-maximal effective concentration: 3.5 nM
The estimate for compound 4 lay 1.1-fold (0.04 log units) below the measured number; the range from low to high includes it.
By their numbers in this assay, from the lowest: compounds 3, 4, 1 and 2 (each within the scatter of the next, the first and the last beyond it).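

In this assay, within the data shown here, the exchange gives a 1.9-fold higher number from compound 3 to compound 4 (0.29 log units; within the scatter), the first reading of a change made in one place only. At a saturated chain carbon bound to an amine nitrogen, a five-membered aromatic ring with a sulfur atom and one hydrogen-bond acceptor can therefore replace an open 2-methylprop-1-en-1-yl group with a double bond and no acceptor, without a difference that can be told from the scatter. Nothing at hand accounts for this match, so the finding remains a description of this single exchange.

Left open is whether this tolerance is particular to thiophen-2-yl or extends to phenyl or furan-2-yl on the same carbon, and whether a saturated 3-methylbutyl group would read like the 3-methylbut-2-en-1-yl of compound 3. Also open, going by these compounds, is how the number responds when hydrogen or an ethyl group takes the place of the methyl on the amine nitrogen.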